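Aminopyrazolopyridinone analogues tested against protein kinase C zeta

The compounds below may be only part of what the source reports. "The series", "measured", "known", "first", "only" and "open" are said of these compounds alone.

Measured compounds:
compound 1, `Nc1n[nH]c2cc(CC3CCNCC3)[nH]c(=O)c12`, -56%
compound 2, `Cc1cc2nn(-c3ccccc3)c(N)c2c(=O)[nH]1`, -49%

Of the compounds shown here, two have been measured in an assay on isolated protein for inhibition of protein kinase C zeta type (Homo sapiens), read by mobility shift assay, tested at 30 uM; a lower number here means less inhibition, a higher number more inhibition at the concentration tested (going by the name of the read-out). Compound 1 `Nc1n[nH]c2cc(CC3CCNCC3)[nH]c(=O)c12` gives -56%, and compound 2 `Cc1cc2nn(-c3ccccc3)c(N)c2c(=O)[nH]1` gives -49%. The two numbers lie within the scatter of each other, so neither compound can be set apart from the other, and both read-outs are negative, so no inhibition has been seen at the concentration tested.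

Compound 3 `COc1ccccc1-c1cc2nn(-c3ccccc3)c(N)c2c(=O)[nH]1` is not yet measured. It differs from compound 2 in one place: 2-methoxyphenyl in place of methyl on an aromatic carbon. Within the data shown here, with only two compounds and no measured step of this kind, there is no basis for a large expectation in either direction. The step from compound 2 to compound 3 is expected to be a number 19 percentage points higher from compound 2 to compound 3 (beyond the scatter), an upward movement that may not exceed the scatter. Compound 3 is therefore expected to give about -30% in this assay, within a range from -70% to 20%.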

Compound 3, a percentage reported as inhibition, at one concentration (the size of the read-out at that concentration, not a potency): 4%
Compound 3: the middle estimate sits 34 percentage points below what was measured; the measured number falls inside the stated range.
By their numbers in this assay, from the lowest: compounds 1 and 2 (each within the scatter of the next); then compound 3.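

Among these compounds, putting 2-methoxyphenyl in place of methyl on the aromatic carbon next to the ring nitrogen gives a number 53 percentage points higher from compound 2 to compound 3 (beyond the scatter) in this assay, the first change in this set to lie beyond the scatter. This shows that the read-out responds to the group at this position, which compounds 1 and 2, within the scatter of each other, could not show. No measurement shown here accounts for the size of this step.

The compounds shown leave open whether the step comes from the added aromatic ring or from its methoxy group, and plain phenyl at this carbon would separate the two. Going by these compounds, it also remains open whether an amine or a carboxylic acid on the same carbon would move the read-out in the same direction.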